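This account rests on a few compounds, and the source may have more. Where it says the series, first, only, none or still open, it means among the compounds named here.

Of the compounds shown here, three have so far been measured in a functional assay on NIH3T3 cells for agonist activity at Urotensin-2 receptor (Homo sapiens), with a stated time of 5 days; a higher number here means a larger maximal response, a lower number a smaller maximal response. Compound 1 `Cc1ccc(C(CCN(C)C)NC(=O)C#Cc2ccccc2)cc1` gives 131%. Compound 2 `CN(C)CCC(NC(=O)C#Cc1ccccc1)c1ccc(Cl)cc1` gives 124% in this assay. Compound 3 `COc1ccc(CCC(=O)NC(CCN(C)C)c2ccc(Cl)cc2)cc1`, built on a different core, gives 101% in this assay, the lowest of the three numbers, and its gaps to compound 2 and to compound 1 both lie beyond the usual scatter. The difference between the core of compound 3 and the core of compound 2 is not broken down here.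

Compound 4 `COc1ccc(CCC(=O)NC(CCN(C)C)c2ccc(C)cc2)cc1` has not yet been measured. It differs from compound 3 by methyl in place of chloro on an aromatic carbon. The same kind of change, at a place described in the same words, separates compound 2 from compound 1: methyl in place of chloro on an aromatic carbon. On that pair the step was a number 7 percentage points higher from compound 2 to compound 1 (within the scatter), which lies within the scatter, so the change itself hardly moved the maximal response there.

Carrying that over, a small step is expected here as well: the estimated change is a number 5 percentage points higher from compound 3 to compound 4 (within the scatter), because compound 3 starts from 101% and the only measured example of this change, a number 7 percentage points higher from compound 2 to compound 1 (within the scatter), was small. This rests on a single pair, so the expectation is loose. Compound 4 is therefore expected to give about 106% in this assay. Its likely range is estimated to run from 88% to 126%.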

Compound 4, largest response reached (reported as efficacy), in percent of the reference or control that the assay uses: 67%
The estimate for compound 4 lay 39 percentage points above the measured number, and the stated range ends above it.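

On the core of compound 3, replacing 4-chlorophenyl with 4-methylphenyl gives a number 34 percentage points lower from compound 3 to compound 4 (beyond the scatter), a clear fall in maximal response that stands in contrast to the small step seen earlier. Set side by side, the two pairs show that this change does not carry over unchanged from one core to the other in this assay: the same change on two cores in this assay, a number 7 percentage points higher (within the scatter) from compound 2 to compound 1 and a number 34 percentage points lower (beyond the scatter) from compound 3 to compound 4, 41 percentage points apart, beyond the scatter of two such steps

A result on one core is therefore a poor guide to the same swap on the other core in this small set, but two pairs cannot show which part of the cores makes the difference, nor how the swap would behave on any third core.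

The compounds shown leave open whether other groups on the same aromatic carbon, such as fluoro, methoxy or an amine, would behave alike on both cores or would again part ways between them. On these data alone, it also remains open whether the fall seen on the core of compound 3 belongs to methyl alone or would extend to a longer chain such as ethyl or propyl at that place.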